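The source may hold more compounds than are shown below. What is called first, only, known or untested is meant among the compounds shown, and "the series" means these compounds.

Measured so far:
Compound 1, `N#Cc1ccc(NC(=O)c2ccc(F)cc2O)cc1`, gives 3150 nM in a functional assay on KG-1 cells (Homo sapiens) for cytotoxicity, read by luminescence and CellTiter-Glo, with a stated time of 3 days; on this read-out lower numbers stand for stronger inhibition and higher numbers for weaker inhibition.
Compound 2, `O=C(Nc1ccc(C(F)(F)F)cc1)c1ccc(F)cc1O`, gives 740 nM.
Compound 3, `O=C(Nc1ccc(C(F)(F)F)cc1)c1cc(Br)c(F)cc1O`, gives 820 nM.

Among these three numbers compound 2 has the lowest, though compound 3 sits so close that the two cannot be told apart; only compound 1 stands clearly apart, as the step of a 4.3-fold lower number from compound 1 to compound 2 (0.63 log units; beyond the scatter) shows.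

The next compound, compound 4, `O=C(Nc1ccc(C(F)(F)F)cc1)c1ccc(Br)cc1O`, differs from compound 2 in one place: bromo in place of fluoro on an aromatic carbon. The fluoro that leaves and the bromo that enters sit on the ring that carries the hydroxy group, while the trifluoromethyl on the other ring is untouched.

Two measured steps exist, and neither matches this change exactly. The step of a 4.3-fold lower number from compound 1 to compound 2 (0.63 log units; beyond the scatter) swapped cyano for trifluoromethyl on the other ring and was modest but beyond the scatter. The step of a 1.1-fold higher number from compound 2 to compound 3 (0.04 log units; within the scatter) brought a bromo onto the hydroxy-bearing ring, at a different aromatic carbon, and stayed within the scatter. Only the second bears loosely on the present change, and it suggests that a bromo on that ring is tolerated. For compound 4 in this assay a step of a 1.1-fold higher number from compound 2 to compound 4 (0.03 log units; within the scatter) is therefore expected, within the scatter. The estimate for compound 4 is 800 nM, with a range from 350 nM to 1800 nM.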

Compound 4, half-maximal inhibitory concentration: 340 nM
Estimate against measurement, compound 4: 2.4-fold (0.37 log units) above; the measured number lies below the stated range.
By their numbers in this assay, from the lowest: compound 4; then compounds 2 and 3 (each within the scatter of the next); then compound 1.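

In this assay, the aromatic carbon meta to a hydroxy group and para to a large group responds to the atom it carries: bromo in place of fluoro there gives a modest change beyond the scatter (a 2.2-fold lower number from compound 2 to compound 4 (0.34 log units; beyond the scatter)). For the compounds shown here, the only earlier bromo change on this ring behaved differently, staying within the scatter (a 1.1-fold higher number from compound 2 to compound 3 (0.04 log units; within the scatter)), but in that step bromo replaced a hydrogen at another carbon and the fluoro stayed in place, so it said little about the atom at this position. Nothing measured here gives a reason why bromo and fluoro differ at this carbon.

The compounds shown leave open what a chloro, a methyl, a methoxy or an amine would give at this same carbon, and so whether the number keeps falling as the atom or group there grows or bromo is a special case. Also open, on these data alone, is whether the same swap would have a similar effect on the core of compound 1, which carries cyano in place of trifluoromethyl on the other ring.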